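This account rests on a few compounds, and the source may have more. Where it says the series, first, only, none or still open, it means among the compounds named here.

Compound 1 `CC(C)c1ccc(-c2nc(SCc3cn(CC(=O)NC(=O)Nc4ccccn4)nn3)nc(Nc3ccccc3Cl)c2C#N)cc1`: 6790 nM in a functional assay on B16-F10 cells (Mus musculus) for inhibition, read by MTT assay, with a stated time of 72 h; a lower number here means a stronger inhibitor, a higher number a weaker inhibitor.
Compound 2 `CC(C)c1ccc(-c2nc(SCc3cn(CC(=O)NC(=O)Nc4ccccn4)nn3)nc(Nc3cccc([N+](=O)[O-])c3)c2C#N)cc1`: 26400 nM in this assay.
Compound 3 `CC(C)c1ccc(-c2nc(SCc3cn(CC(=O)NC(=O)Nc4ccccn4)nn3)nc(Nc3ccccc3)c2C#N)cc1`: 14300 nM in this assay.

Of these three numbers, compound 3 stands second highest; it sits a 1.8-fold lower number from compound 2 to compound 3 (0.27 log units; within the scatter), and a 2.1-fold higher number from compound 1 to compound 3 (0.32 log units; beyond the scatter). Compound 4 `Cc1ccc(Nc2nc(SCc3cn(CC(=O)NC(=O)Nc4ccccn4)nn3)nc(-c3ccc(C(C)C)cc3)c2C#N)cc1` differs from compound 3 in one spot: methyl in place of hydrogen on an aromatic carbon. Among the measured compounds shown here, no measured step adds a methyl, but two steps touch the same anilino ring. Taking off the chloro gave a modest rise from compound 1 to compound 3, while taking off the nitro gave a fall from compound 2 to compound 3 that stays within the scatter. On that basis the expected step is small: a 1.3-fold lower number from compound 3 to compound 4 (0.11 log units; within the scatter), with no clear direction. Compound 4 is therefore estimated at 11000 nM, within a range from 4000 nM to 35000 nM.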

Compound 4, half-maximal inhibitory concentration: 3060 nM
Compound 4: the middle estimate sits 3.6-fold (0.56 log units) above what was measured, and the stated range ends above it.
By their numbers in this assay, from the lowest: compound 4; then compound 1; then compounds 3 and 2 (each within the scatter of the next).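

Adding one methyl to the anilino ring, para to a large group, gives a 4.7-fold lower number from compound 3 to compound 4 (0.67 log units; beyond the scatter), so this position can respond strongly to a single added carbon. The 4-methylphenyl group also improves on both other substituted rings, with an 8.6-fold lower number from compound 2 to compound 4 (0.94 log units; beyond the scatter) against 3-nitrophenyl and a 2.2-fold lower number from compound 1 to compound 4 (0.35 log units; beyond the scatter) against 2-chlorophenyl , which leaves compound 4 with the lowest number of the four. Nothing measured here accounts for this gain.

Still open, from the compounds shown here alone, is whether the gain is specific to methyl or would extend to a larger ethyl or a methoxy group at this position. Going by these compounds, it is also open whether the same methyl would give a similar step elsewhere on the ring.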